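A few compounds are considered here, and "the series" means these few. Any claim that something is new, unique, unknown or untested is made for them only; others in the source may bear on it.

Compound 1 `Cc1cc(Cl)c(-c2cn(C)cn2)cc1NC(=O)c1ccc(OCc2ccccn2)cc1` gives 3.1 in a physicochemical assay for lipophilicity; a lower number here means a more polar compound, a higher number a more lipophilic compound.
Compound 2 `Cc1cc(C)c(-c2cn(C)cn2)cc1NC(=O)c1ccc(OCc2ccccn2)cc1` gives 3 in this assay.
Compound 3 `Cc1cc(C)c(-c2nc3ccccc3[nH]2)cc1NC(=O)c1ccc(OCc2ccccn2)cc1` gives > 3.5 in this assay, and this is a limit of the measurement rather than a number.

Compound 3 therefore stands at the upper edge of what the measurement reports, as the limit of > 3.5 in this assay, at which 1 of the 3 values shown sits, shows. The step to compound 4 `Cc1cc(C)c(-c2ccc(N)cn2)cc1NC(=O)c1ccc(OCc2ccccn2)cc1` changes the group attached to the shared core: 5-aminopyridin-2-yl in place of 1H-benzimidazol-2-yl on an aromatic carbon. Among the compounds with values here, of the measured steps, only the one in which this same position was altered bears on it: a number at least 0.50 log units higher from compound 2 to compound 3 (beyond the scatter). Replacing a small five-membered ring by a bicyclic group raised the reading beyond the scatter, so taking the bicyclic group away again and putting in a single six-membered ring with an amino group is expected to move the reading downward in this assay, with a size that cannot be fixed precisely since compound 3 has only a limit. Compound 4 is expected to come out at 3.2, between 2.7 and 3.7, which means an estimated step of a number at least 0.30 log units lower from compound 3 to compound 4 (that floor lies within the scatter).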

Compound 4, distribution coefficient: 3.2
Estimate against measurement, compound 4: no gap at the digits printed, within the range that was stated.
By their numbers in this assay, from the lowest: compounds 2, 1 and 4 (each within the scatter of the next). At a limit, above all of these: compound 3.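

Compound 4 puts a third group at this position, and in this assay the exchange of one single-ring group for another, 5-aminopyridin-2-yl in place of 1-methyl-1H-imidazol-4-yl, gives a number 0.20 log units higher from compound 2 to compound 4 (within the scatter), so a six-membered ring and a five-membered ring are not told apart here. Set against the bicyclic 1H-benzimidazol-2-yl, the same group gives a number at least 0.30 log units lower from compound 3 to compound 4 (that floor lies within the scatter), which fixes only a floor for the size of the step. Compound 3 stands at a limit rather than a number, so how far the reading truly falls cannot be said: the limit of > 3.5 in this assay, at which 1 of the 4 values shown sits.

Going by these compounds, what a plain pyridin-2-yl ring without the amino group, or a ring bearing a carboxylic acid, would give at this position remains open. Also open, on these data alone, is how 5-aminopyridin-2-yl would read on the chloro-bearing core of compound 1.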